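Chloro in Place of Hydrogen on a Potent Pair

This account rests on a few compounds, and the source may have more. Where it says the series, first, only, none or still open, it means among the compounds named here.

In a functional assay on HeLa cells (Homo sapiens) for cytotoxicity, read by sulforhodamine B assay (a lower number here means a stronger inhibitor, a higher number a weaker inhibitor), compound 1 (`CSc1ccc(N(C)c2nc(C)nc3ccccc23)cc1`) gives 1.1 nM and compound 2 (`CSc1ccc(N(C)c2ncnc3ccccc23)cc1`) gives 7.3 nM in the same test. Compound 2 therefore holds the higher of the two numbers and is the weaker inhibitor of the pair. The next compound, compound 3 (`CSc1ccc(N(C)c2nc(Cl)nc3ccccc23)cc1`), comes from compound 2 by one change (chloro in place of hydrogen on an aromatic carbon) with chloro in place of hydrogen on an aromatic carbon between two ring nitrogen atoms. Compound 1 carries its methyl on that same carbon.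

Among the measured compounds shown here, only one measured step bears on this change. It is a 6.6-fold higher number from compound 1 to compound 2 (0.82 log units; beyond the scatter) and marks hydrogen in place of methyl on that carbon. Read in reverse, it shows compound 1 with its methyl holding the lower number, while compound 2 with hydrogen holds the higher. For the measured compounds named here, no chloro compound has yet been measured, so this single step is only a rough guide, and the expectation stays cautious. A modest fall in the number is expected, estimated as a 2.4-fold lower number from compound 2 to compound 3 (0.39 log units; beyond the scatter) on this evidence. The estimate for compound 3 is 3 nM with an expected range from 1 nM to 9 nM in this test.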

Compound 3, half-maximal inhibitory concentration: 3.2 nM
The estimate for compound 3 lay 1.1-fold (0.03 log units) below the measured number; the range from low to high includes it.
By their numbers in this assay, from the lowest: compound 1; then compound 3; then compound 2.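

In this assay, the carbon between two ring nitrogen atoms now has a second group on record that gives a lower number than hydrogen: chloro in place of hydrogen produces a step down (a 2.3-fold lower number from compound 2 to compound 3 (0.36 log units; beyond the scatter)), so this fall is no longer tied to methyl alone. The two groups are not interchangeable, however, since chloro in place of methyl produces a step up (a 2.9-fold higher number from compound 1 to compound 3 (0.46 log units; beyond the scatter)), which places chloro in the middle of the three compounds, with methyl lowest, hydrogen highest and every gap among them beyond the usual scatter. Nothing shown here explains this order, and the data offer no independent measurement that bears on either change.

With only hydrogen, methyl and chloro at this carbon, three compounds cannot show whether the order would hold for other small groups such as fluoro, methoxy or an amine, or for a longer chain such as ethyl or propyl. They also leave open whether the same changes would give steps of similar size on a core carrying a different group in place of the methylthio-bearing ring.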